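The source may hold more compounds than are shown below. What is called first, only, known or untested is meant among the compounds shown, and "the series" means these compounds.

Compound 1 `CNc1nc(/C=C/c2ccccc2)nc2ccsc12` is the starting point in a functional assay on L02 cells (Homo sapiens) for inhibition, read by Griess assay, with stated times of 1 h and 24 h; on this read-out lower numbers stand for stronger inhibition and higher numbers for weaker inhibition. Compound 1 gives > 1000000 nM, which is a limit of the assay and not a number. Compound 2 `CCCCNc1nc(/C=C/c2ccccc2)nc2ccsc12` gives > 1000000 nM, again only a limit. Compound 3 `Brc1ccc(Nc2nc(/C=C/c3ccccc3)nc3ccsc23)cc1` gives > 1000000 nM, also only a limit. Every result so far is therefore the same, (the limit of > 1000000 nM in this assay, at which 3 of the 3 values shown sit), and compound 1 cannot be ranked against the other two.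

Compound 4 `CNc1nc(/C=C/c2ccco2)nc2ccsc12` keeps the methyl on the nitrogen of compound 1 and changes another part of the molecule: furan-2-yl in place of phenyl on a double-bonded chain carbon bound to a double-bonded chain carbon. Within the data shown here, no measured compound changes this group, so the data offer no direct precedent. The three measured steps all alter the substituent on the nitrogen: a step that the two limits leave unreadable from compound 1 to compound 2, a step that the two limits leave unreadable from compound 1 to compound 3 and a step that the two limits leave unreadable from compound 2 to compound 3. None has a readable size, so they give only weak guidance, showing that these changes never brought a compound to a measurable number.

The expectation in this assay is therefore no step beyond the usual scatter and no favoured direction. The expected step is a number no higher from compound 1 to compound 4 (the limit leaves the size open). For compound 4 the estimated value is 1000000 nM, with an expected range of 200000 nM to 2000000 nM.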

Compound 4, half-maximal inhibitory concentration: 811000 nM
Compound 4: the middle estimate sits 1.2-fold (0.09 log units) above what was measured; the range from low to high includes it.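

In this assay compound 4 is the first compound shown to give a readable number, 811000 nM, so with furan-2-yl in this place on the double-bonded chain carbon, the series reaches the measurable scale for the first time. The change reads as an at least 1.2-fold lower number from compound 1 to compound 4 (0.09 log units; that floor lies within the scatter), but this is only a floor: compound 1 has just a limit, so the true step could be larger or could stay within the scatter. The steps among compound 1, compound 2 and compound 3 cannot be read, and the limit still describes most of this small set: the limit of > 1000000 nM in this assay, at which 3 of the 4 values shown sit.

Going by these compounds, it remains open whether the oxygen of the furan matters or only the exchange of a six-membered ring for a five-membered one, and a thiophen-2-yl or pyridin-2-yl group in the same place would help to separate the two. On these data alone, it is also open whether furan-2-yl would give a number with the butyl of compound 2 or the 4-bromophenyl of compound 3 on the nitrogen, and what a small amine on the furan ring would do.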